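Replacing the 4-methylphenyl group of compound 1 with hydrogen

The compounds below may be only part of what the source reports. "The series", "measured", "known", "first", "only" and "open" are said of these compounds alone.

Within the data shown here, in a functional assay on A-375 cells (Homo sapiens) for antiproliferative activity, read by MTT assay, with a stated time of 72 h (a lower number here means a stronger inhibitor, a higher number a weaker inhibitor), compound 1 (`COc1ncc(-c2ccc3c(c2)N(c2ccc(C)cc2)C(=O)CO3)cc1NS(=O)(=O)c1ccc(F)cc1`) gives 12900 nM as the only number in hand. Compound 2 (`COc1ccc(N2C(=O)COc3ccc(-c4ccc(O)cc4)cc32)cc1`) reads > 40000 nM and that value is a limit of the assay. Compound 3 (`COc1ncc(-c2ccc3c(c2)NC(=O)CO3)cc1NS(=O)(=O)c1ccc(F)cc1`) has hydrogen in place of 4-methylphenyl on an amide-type nitrogen in a ring. Among the measured compounds shown here, no measured step covers this change, so only a moderate move towards weaker inhibition in this assay is expected. The expected step is one (a 1.7-fold higher number from compound 1 to compound 3 (0.23 log units; within the scatter)) of modest size. For compound 3 the estimate is 22000 nM with an expected range (9000 nM to 50000 nM).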

Compound 3, half-maximal inhibitory concentration: 26300 nM
Compound 3: middle estimate off by 1.2-fold (0.08 log units), on the low side; low and high end bracket the measured number.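

Among these compounds, replacing 4-methylphenyl with hydrogen on the amide-type nitrogen in a ring gives a 2.0-fold higher number from compound 1 to compound 3 (0.31 log units; beyond the scatter) in this assay, the only step read at this position. The group therefore counts for a modest amount, and compound 3 still gives a number without it. Compound 2 stands at a limit, which leaves little readable range above compound 3: the limit of > 40000 nM in this assay, at which 1 of the 3 values shown sits.

As far as these compounds go, whether a small methyl or a benzyl group on this nitrogen would give a lower number than 4-methylphenyl stays open. So does the effect of an amine on the 4-methylphenyl ring.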